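Dimethyl substitution on the pyrrolidine amide: compound 4

The source may report more compounds than this note shows. Statements on the series, on what has been measured and on what is new or still open speak of the compounds shown alone.

Compound 3 `COc1cc(C(=O)N2CCCC2)cc2nc(NCc3cccc(Cl)c3)oc12` gives 180 nM in an assay on isolated protein for inhibition of thyroid hormone receptor beta (Homo sapiens), read by fluorescence, with a stated time of 30 min (on this read-out lower numbers stand for stronger inhibition and higher numbers for weaker inhibition), the highest number of the three measured compounds: compound 1 `CCn1cccc(-c2ccc(N3C[C@H](CNC(=O)c4ccc(Cl)s4)OC3=O)cc2OC)c1=O` gives 61 nM, and compound 2 `CCCN(CC1CCOC1)C(=O)c1cc(OC)c2oc(NCc3cccc(Cl)c3)nc2c1` gives 12 nM. Compound 4 `COc1cc(C(=O)N2CCCC2(C)C)cc2nc(NCc3cccc(Cl)c3)oc12` carries 2,2-dimethylpyrrolidin-1-yl in place of pyrrolidin-1-yl on a carbonyl carbon. Among the measured compounds shown here, the only measured step on the carbonyl carbon, a 15-fold higher number from compound 2 to compound 3 (1.18 log units; beyond the scatter), exchanged the entire amine and is not the same change; it shows that a larger substituent on the carbonyl carbon has given a lower number once. For the measured compounds named here, on that basis a modest lowering is expected for compound 4, a 1.8-fold lower number from compound 3 to compound 4 (0.26 log units; within the scatter), with wide uncertainty because no ring-methylated analogue has been measured. Compound 4 is estimated at 100 nM, range 30 nM to 400 nM.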

Compound 4, half-maximal inhibitory concentration: 47 nM
Estimate against measurement, compound 4: 2.1-fold (0.33 log units) above; low and high end bracket the measured number.
By their numbers in this assay, from the lowest: compound 2; then compounds 4 and 1 (each within the scatter of the next); then compound 3.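

On the carbonyl carbon, 2,2-dimethylpyrrolidin-1-yl in place of pyrrolidin-1-yl gives a 3.8-fold lower number from compound 3 to compound 4 (0.58 log units; beyond the scatter) in this assay, so a change confined to the ring, with the ring itself kept, already moves the number beyond the scatter. The ((oxolan-3-yl)methyl)(propyl)amino group still holds the lower number, with a 3.9-fold higher number from compound 2 to compound 4 (0.59 log units; beyond the scatter). Nothing available bears on the reason for either step. The compounds shown leave open how a 2-methylpyrrolidin-1-yl or a piperidin-1-yl group would read on this carbonyl carbon, and whether any cyclic amine can match compound 2.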